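Trimming the Sulfonamide Tail: Expected Microsomal Stability of Compound 4

This account rests on a few compounds, and the source may have more. Where it says the series, first, only, none or still open, it means among the compounds named here.

Measured compounds:
compound 1 `Cc1ccccc1S(=O)(=O)NC(=O)c1ccc(Nc2nc(NC3(c4ccc(Cl)cc4)CC3)nc(OCC(F)(F)F)n2)cc1` gives 100% in an ADME assay on microsomes from liver (Homo sapiens) for metabolic stability, with a stated time of 10 min; a higher number here means that more of the compound is left, a lower number that less of the compound is left
compound 2 `CCCCCNc1nc(Nc2ccc([N+](=O)[O-])cc2)nc(OCC(F)(F)F)n1` gives 74% in this assay
compound 3 `CNC(=O)NCCS(=O)(=O)NC(=O)c1ccc(Nc2nc(NC3(c4ccc(Cl)cc4)CC3)nc(OCC(F)(F)F)n2)cc1` gives 97% in this assay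

Compound 3 stands second highest of the three numbers in this assay. Its nearest neighbour is compound 1, whose value lies within the scatter of it, so the two cannot be told apart; its furthest is compound 2, which lies beyond the scatter below it.

The unmeasured compound 4 `NCCS(=O)(=O)NC(=O)c1ccc(Nc2nc(NC3(c4ccc(Cl)cc4)CC3)nc(OCC(F)(F)F)n2)cc1` differs from compound 3 in one place: hydrogen in place of methylcarbamoyl on an amine nitrogen. The tail on the sulfonyl sulfur is thus shortened while the rest of the molecule stays unchanged.

Going by the values given here, one measured step bears on this part of the structure. Replacing the group on the sulfonyl sulfur gave a number 3 percentage points lower from compound 1 to compound 3 (within the scatter), a change lying within the scatter. Both compounds with the shared core and the chlorophenyl-cyclopropyl group sit near the top of the scale in this assay. A further change on the same tail is therefore expected to move the number by a number 4 percentage points lower from compound 3 to compound 4 (within the scatter), that is, not beyond the scatter.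

Compound 4 is accordingly estimated at 93% in this assay, expected between 78% and 100%.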

Compound 4, percent of the compound remaining: 100%
Estimate against measurement, compound 4: 7 percentage points below; the range from low to high includes it.
By their numbers in this assay, from the lowest: compound 2; then compounds 3, 1 and 4 (each within the scatter of the next).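

Taking methylcarbamoyl off the amine nitrogen gives, in this assay, a number 3 percentage points higher from compound 3 to compound 4 (within the scatter), so the tail can lose these 4 heavy atoms without a difference that this read-out can resolve. Compared directly with 2-methylphenyl on the sulfonyl sulfur, the shorter 2-aminoethyl gives no change at the digits printed from compound 1 to compound 4 (within the scatter). Going by these compounds alone, the earlier compounds offered only one exchange at this position, whereas 2-methylphenyl, 2-((methylcarbamoyl)amino)ethyl and 2-aminoethyl now form a set of three groups on the shared core whose numbers cannot be told apart.

All three numbers lie close to the top of the scale, so these compounds cannot show whether a carboxylic acid, a tertiary amine or a longer alkyl chain on the sulfonyl sulfur would also leave the reading within the scatter, and they say nothing about stability over a longer incubation. No measurement is available to explain why these three groups give readings that cannot be told apart.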